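Adding a methoxy group to compound 3

The source may report more compounds than this note shows. Statements on the series, on what has been measured and on what is new or still open speak of the compounds shown alone.

In a functional assay on 786-0 cells (Homo sapiens) for inhibition, read by sulforhodamine B assay, with a stated time of 48 h (on this read-out higher numbers stand for weaker inhibition of growth and lower numbers for stronger inhibition of growth), compound 3 `CC(C)(C)NCc1c(C(=O)O)nn(-c2ccc(Cl)cc2)c1-c1ccccc1` stands only as a limit, > 652000 nM. Compound 2 `CC(C)(C)NCc1c(C(=O)O)nn(-c2ccc(Cl)cc2)c1-c1ccc(F)cc1` gives 204000 nM. Hydrogen in place of fluoro on an aromatic carbon gave an at least 3.1-fold higher number from compound 2 to compound 3 (0.50 log units; beyond the scatter), a step beyond the scatter. Compound 1 `CCOC(=O)c1nn(-c2ccc(Cl)cc2)c(-c2ccc(OC)cc2)c1CNC(C)(C)C`, which also carries the 4-methoxyphenyl group, gives 119000 nM; > 523000 nM (2 entries). Compound 4 `COc1ccc(-c2c(CNC(C)(C)C)c(C(=O)O)nn2-c2ccc(Cl)cc2)cc1` differs from compound 3 by methoxy in place of hydrogen on an aromatic carbon. Going by compound 2 at 204000 nM, a modest step to a lower number is expected in this assay. The expected step is an at least 2.6-fold lower number from compound 3 to compound 4 (0.41 log units; beyond the scatter). For compound 4 the estimate is 250000 nM, with an expected range from 100000 nM to 650000 nM.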

Compound 4, concentration for 50% growth inhibition: > 605000 nM
Compound 4 was reported as a limit (the forecaster's own chance of this, stated with the estimate: 35%); at least 2.4-fold (0.38 log units) between middle value and limit.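

In this assay, methoxy in place of fluoro on the aromatic carbon gave an at least 2.9-fold higher number from compound 2 to compound 4 (0.47 log units; beyond the scatter), so at this position the two groups are not interchangeable. Compound 4 stands only as a limit, > 605000 nM. The step from hydrogen to methoxy cannot be read, both values being limits, so no gain of methoxy over hydrogen can be stated, and among these three carboxylic acids only the fluoro compound gives a single number.

From the compounds shown here alone, whether an amine or trifluoromethyl at this position would give a lower number stays open. Also open is how the ethyl ester compares with the carboxylic acid of compound 4, given the split entries of its methoxy partner: the several entries of compound 1 in this assay, 119000 nM; > 523000 nM (2 entries)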